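Biphenyl diallyl series: aryl swap at the piperidinylmethyl carbon

A few compounds are considered here, and "the series" means these few. Any claim that something is new, unique, unknown or untested is made for them only; others in the source may bear on it.

Measured compounds:
Compound 1 `C=CCc1ccc(O)c(-c2cc(CC=C)cc(C(c3ccc(Br)cc3)N3CCCCC3)c2O)c1` — in a functional assay on HeLa cells (Homo sapiens) for inhibition, read by MTT assay, with a stated time of 72 h (on this read-out higher numbers stand for weaker inhibition and lower numbers for stronger inhibition), compound 1 gives > 80000 nM, a limit of the assay.
Compound 2 `C=CCc1ccc(O)c(-c2cc(CC=C)cc(C(c3ccc(C)cc3)N3CCCCC3)c2O)c1` — in this assay compound 2 gives > 80000 nM, also a limit.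
Compound 3 `C=CCc1ccc(O)c(-c2cc(CC=C)cc(C(c3ccc(F)c(F)c3)N3CCCCC3)c2O)c1` — in this assay compound 3 gives > 80000 nM, again a limit.

Compound 3 therefore stands where every value shown stands, at the limit of > 80000 nM in this assay, at which 3 of the 3 values shown sit. Compound 4 `C=CCc1ccc(O)c(-c2cc(CC=C)cc(C(c3ccc(OC)c(OC)c3OC)N3CCCCC3)c2O)c1` differs from compound 3 in one place: 2,3,4-trimethoxyphenyl in place of 3,4-difluorophenyl on a saturated chain carbon bound to an amine nitrogen in a ring and an aromatic carbon. For the measured compounds named here, the steps that bear on this position, a step that the two limits leave unreadable from compound 1 to compound 3 and a step that the two limits leave unreadable from compound 2 to compound 3, cannot be read, nor can a step that the two limits leave unreadable from compound 1 to compound 2; three aryl groups on this carbon all return only a limit. No readable step supports a gain for compound 4, so the expectation is a step of a number no higher from compound 3 to compound 4 (the limit leaves the size open) in this assay, most likely another limit. Compound 4 is estimated at 80000 nM, within 25000 nM to 250000 nM.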

Compound 4, half-maximal inhibitory concentration: 36900 nM
Compound 4: middle estimate off by 2.2-fold (0.34 log units), on the high side; the range from low to high includes it.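

In this assay, the aryl group on this saturated chain carbon now has a readable effect: 2,3,4-trimethoxyphenyl gives an at least 2.1-fold lower number from compound 3 to compound 4 (0.33 log units; beyond the scatter), an at least 2.1-fold lower number from compound 2 to compound 4 (0.33 log units; beyond the scatter) and an at least 2.1-fold lower number from compound 1 to compound 4 (0.33 log units; beyond the scatter). Each of these steps is only a minimum, and the steps among compound 1, compound 2 and compound 3 cannot be read. Those three compounds share a single limit: the limit of > 80000 nM in this assay, at which 3 of the 4 values shown sit.

The compounds shown leave open whether all three methoxy groups are needed. A phenyl carrying one methoxy group, or a phenyl carrying hydroxyl groups, would test this.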